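Diaryl thiourea series: aryl swap on the thiourea nitrogen

The source may report more compounds than this note shows. Statements on the series, on what has been measured and on what is new or still open speak of the compounds shown alone.

Measured so far:
compound 1 `CNC(=O)c1ccc(Oc2cccc(NC(=S)Nc3cc(C(F)(F)F)cc(C(F)(F)F)c3)c2)nc1` — 2670 nM
compound 2 `CNC(=O)c1ccc(Oc2cccc(NC(=S)Nc3ccc(F)c(C(F)(F)F)c3)c2)nc1` — 13300 nM
compound 3 `CNC(=O)c1ccc(Oc2cccc(NC(=S)Nc3ccc(Cl)cc3Cl)c2)nc1` — 20700 nM

In a functional assay on MDA-MB-231 cells (Homo sapiens) for antiproliferative activity, read by MTT assay (a higher number here means a weaker inhibitor, a lower number a stronger inhibitor), compound 3 gives the highest of the three numbers. Its nearest neighbour is compound 2, whose value lies within the scatter of it, so no order between compound 2 and compound 3 can be read. Compound 1 sits far lower, beyond the scatter. For the measured compounds named here, no single-point step between measured compounds is available.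

Compound 4 `CNC(=O)c1ccc(Oc2cccc(NC(=S)Nc3ccc(C)cc3)c2)nc1` differs from compound 3 in one place: 4-methylphenyl in place of 2,4-dichlorophenyl on an amide-type nitrogen. Going by the values given here, with no measured step of this kind, the expectation rests on the spread seen so far. The step in this assay from compound 3 to compound 4 is expected to be modest and toward a higher number, a 1.4-fold higher number from compound 3 to compound 4 (0.16 log units; within the scatter). Compound 4 is therefore estimated at 30000 nM, with a range from 8000 nM to 100000 nM.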

Compound 4, half-maximal inhibitory concentration: 29500 nM
The estimate for compound 4 lay 1.0-fold (0.01 log units) above the measured number, and the stated range covers the measured number.
By their numbers in this assay, from the lowest: compound 1; then compounds 2, 3 and 4 (each within the scatter of the next, the first and the last beyond it).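

In this assay the change from 2,4-dichlorophenyl to 4-methylphenyl on the amide-type nitrogen gives a 1.4-fold higher number from compound 3 to compound 4 (0.15 log units; within the scatter) and so allows no order between these two aryl groups. This first single-point step at this position shows that both chlorines can give way to a methyl group with no readable change in this assay. Nothing available explains this result. Still open, from the compounds shown here alone, is how unsubstituted phenyl or 4-methoxyphenyl would read on this nitrogen. Also open, going by these compounds, is whether an aryl group carrying an amine or a carboxylic acid would stay within the scatter of compound 3.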